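A few compounds are considered here, and "the series" means these few. Any claim that something is new, unique, unknown or untested is made for them only; others in the source may bear on it.

Measured in a functional assay on the whole organism (blood, strain Wistar-Okamoto) with Rattus norvegicus as the target, with a stated time of 5 days; on this read-out higher numbers stand for an effect only at larger amounts of compound and lower numbers for an effect already at smaller amounts:
- compound 1 `CCCC/N=C(\NC#N)Nc1cccnc1`: 20 mg/kg
- compound 2 `CCCCC/N=C(\NC#N)Nc1cccnc1`: 20 mg/kg
- compound 3 `CCCCCCC/N=C(\NC#N)Nc1cccnc1`: a limit only, > 50 mg/kg

Compound 1 stands level with compound 2, no change at the digits printed from compound 1 to compound 2 (within the scatter). The third value is a limit of this assay, not a number (the limit of > 50 mg/kg in this assay, at which 1 of the 3 values shown sits).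

Compound 4 `CCCCC(CC)C/N=C(\NC#N)Nc1cccnc1` differs from compound 1 by butyl in place of hydrogen on a saturated chain carbon bound to two saturated chain carbons. Among the compounds with values here, no measured step matches this change; the nearest are the chain extensions an at least 2.5-fold higher number from compound 1 to compound 3 (0.39 log units; beyond the scatter) and an at least 2.5-fold higher number from compound 2 to compound 3 (0.39 log units; beyond the scatter), both at least modest toward higher numbers. Since compound 4 carries more chain carbons than compound 3, a step toward a higher number is expected, and a limit rather than a number is quite possible.

Estimated: from compound 1, a 3.0-fold higher number from compound 1 to compound 4 (0.48 log units; beyond the scatter). For compound 4 the expected value is 60 mg/kg, within a range of 20 mg/kg to 150 mg/kg.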

Compound 4, minimum effective dose: > 50 mg/kg
Compound 4: no number, only a limit (the forecaster's own chance of this, stated with the estimate: 60%); the middle value is on the limit's open side.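

Butyl in place of hydrogen on a saturated chain carbon bound to two saturated chain carbons gives an at least 2.5-fold higher number from compound 1 to compound 4 (0.39 log units; beyond the scatter) in this assay, so the read-out also moves at this place, not only on extension of the straight chain. Compound 4 gives > 50 mg/kg, which is a limit and not a number. The size of the step therefore stays unread, and the limit now holds a second compound: the limit of > 50 mg/kg in this assay, at which 2 of the 4 values shown sit.

Open, from the compounds shown here alone, is whether a smaller group at this place, such as methyl or ethyl, stays level with compound 1. Also open, going by these compounds, is how an amine or a hydroxyl on the chain would read.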